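Microsomal stability: from compound 2 to compound 4

This account rests on a few compounds, and the source may have more. Where it says the series, first, only, none or still open, it means among the compounds named here.

Measured so far:
compound 1 `COc1ccc(-c2c(C)sc3c(N4CC[C@@H](NC(C)=O)C4)nc(C)nc23)cc1OC`: > 95%
compound 2 `COc1ccc(-c2c(C)nc3c(N4CC[C@@H](NC(=O)OC5CCCCC5)C4)cc(C)nn23)cc1OC`: > 95%
compound 3 `COc1ccc(-c2c(C)nc3c(N4CCN(C(=O)OC(C)(C)C)C4)cc(C)nn23)cc1OC`: > 95%

In an ADME assay on microsomes from liver (Homo sapiens) for metabolic stability, read by LC-MS, with NADPH named in the record, with a stated time of 60 min, tested at 1 uM, in the absence of a further agent (on this read-out lower numbers stand for a less stable compound and higher numbers for a more stable compound), compound 2 gives > 95%, which is a limit of the assay and not a number. Compound 1 sits at the same limit. Compound 3 sits at the same limit. So compound 2 stands with the other two at the limit of > 95% in this assay, at which 3 of the 3 values shown sit, and no order among the three can be read.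

Compound 4 `COc1ccc(-c2c(C)nc3c(N4CC[C@@H](n5cc(-c6ccccc6)nn5)C4)cc(C)nn23)cc1OC` is not yet measured. It differs from compound 2 in one place: 4-phenyl-1H-1,2,3-triazol-1-yl in place of (cyclohexyloxycarbonyl)amino on a saturated ring carbon.

Within the data shown here, no measured step stands beside this change. With every value at the limit, the expected step from compound 2 to compound 4 is a number at least 7 percentage points lower from compound 2 to compound 4 (that floor lies within the scatter), a small drop at most, within the scatter. Compound 4 is expected to give 88% in this assay, between 60% and 99%.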

Compound 4, percent of the compound remaining: "unstable" (no number reported)
Compound 4 has no reported number here; the estimate stays without a comparison.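

In this assay, among these compounds, compound 4 gives "unstable" (no number reported), so no step from compound 2 to compound 4 can be read. The compounds shown leave open how large any difference between these two compounds is.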